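The compounds below may be only part of what the source reports. "The series", "measured", "known", "first", "only" and "open" are said of these compounds alone.

This account concerns compound 2 `O=C(CCc1ccccc1)Nc1nc2ccccc2c(=O)s1` and compound 4 `O=C(CCCc1ccccc1)Nc1nc2ccccc2c(=O)s1`, which share a core and an amide-linked chain ending in a phenyl ring. In an assay on CHO cells for displacement of a labelled ligand from adenosine receptor A3 (Homo sapiens), read by scintillation counting, with a stated time of 60 min (a lower number here means a stronger inhibitor, a higher number a weaker inhibitor), compound 2 gives 390 nM. For the measured compounds named here, of the three values known, that of compound 2 is the only outright number. Compound 1 `O=C(CCCc1ccccc1)Nc1nc2ccsc2c(=O)s1` carries the same chain as compound 4 on a different core. In this assay compound 1 gives > 1000 nM, which is a limit. Compound 3 `COc1cccc(C#CC(=O)Nc2nc3ccccc3c(=O)s2)c1`, whose chain holds an alkyne, gives > 1000 nM in this assay, also a limit. The change from compound 2 to compound 4 is benzyl in place of phenyl on a saturated chain carbon, two bonds along the chain from a carbonyl carbon. Going by the values given here, no measured pair of compounds shows this step, so its size is not known. Because compound 1 with the same longer chain sits at the limit of > 1000 nM in this assay, at which 2 of the 3 values shown sit, the step is expected to run toward weaker binding rather than to stay within the scatter. The step is expected to amount to a 2.3-fold higher number from compound 2 to compound 4 (0.36 log units; beyond the scatter). Compound 4 is therefore estimated to give 900 nM in this assay, with a likely range from 300 nM to 3000 nM.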

Compound 4, inhibition constant: > 1000 nM
Compound 4 was reported as a limit (the forecaster's own chance of this, stated with the estimate: 40%); middle value at least 1.1-fold (0.04 log units) from the limit.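

For the compounds shown here, for the first time a step on this chain can be read on the shared core: benzyl in place of phenyl on a saturated chain carbon, two bonds along the chain from a carbonyl carbon, gives an at least 2.5-fold higher number from compound 2 to compound 4 (0.40 log units; beyond the scatter) in this assay. Its size has only a lower bound, as the reading for compound 4 is a limit. Compound 2 therefore remains the only compound here with an outright number, while compound 4 joins the others at a limit: the limit of > 1000 nM in this assay, at which 3 of the 4 values shown sit.

Compound 1 and compound 4 carry the same chain on different cores, but with both at a limit, any step between them cannot be read. Also open, from the compounds shown here alone, are how much weaker compound 4 truly is and whether a shorter chain, or an amine on the phenyl ring, would bind more strongly than compound 2.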